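The source may hold more compounds than are shown below. What is called first, only, known or untested is meant among the compounds shown, and "the series" means these compounds.

Compound 1, with the structure `CC1CN(C(N)=S)N=C1c1ccccc1`, carries a thiocarboxamide on its ring nitrogen. In an ADME assay on KB cells (Homo sapiens) for cytotoxicity, read by MTT assay, with a stated time of 44 h (on this read-out lower numbers stand for stronger inhibition and higher numbers for weaker inhibition), compound 1 gives only a limit, > 100000 nM, and no number. Compound 2, `CC(C)NC(=S)N1CC(C)C(c2ccccc2)=N1`, differs by an isopropyl in place of hydrogen on the amide-type nitrogen. In this assay compound 2 likewise reaches only a limit, > 100000 nM. The step from compound 1 to compound 2 is a step that the two limits leave unreadable from compound 1 to compound 2, so its size cannot be read, because both values sit at the limit of > 100000 nM in this assay, at which 2 of the 2 values shown sit. Compound 3, `CCCCNC(=S)N1CC(C)C(c2ccccc2)=N1`, takes the series one step further: butyl in place of isopropyl on an amide-type nitrogen. For the measured compounds named here, the only measured step that bears on this change is the one from compound 1 to compound 2, and it was unreadable, giving no direction for expectation beyond the scatter. It is therefore expected that compound 3 will also sit at the limit, with an estimated step that the limit leaves unreadable from compound 2 to compound 3. The estimate for compound 3 in this assay is 150000 nM, with a range from 40000 nM to 500000 nM.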

Compound 3, half-maximal inhibitory concentration: > 100000 nM
Compound 3: only a limit was reported; the forecaster's own chance of this, stated with the estimate: 85%; the middle value is on the limit's open side.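

In this assay compound 3 gives > 100000 nM as a limit and no number. For the compounds shown here, no step among compound 1, compound 2 and compound 3 can be read, because all three stand at a limit: the limit of > 100000 nM in this assay, at which 3 of the 3 values shown sit. The compounds shown leave open whether hydrogen, isopropyl or butyl on the amide-type nitrogen makes any difference in this assay.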